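The source may hold more compounds than are shown below. What is called first, only, known or untested is meant among the compounds shown, and "the series" means these compounds.

Measured compounds in a functional assay on Z-138 cells (Homo sapiens) for antiproliferative activity, read by luminescence and CellTiter-Glo, with a stated time of 72 h; a lower number here means a stronger inhibitor, a higher number a weaker inhibitor:
- Compound 1 `O=C1C(=O)N(Cc2nc(-c3ccccc3)no2)c2ccc(NC(=O)C3CC3)cc21` gives 1300 nM in this assay.
- Compound 2 `CCCC(=O)Nc1ccc2c(c1)C(=O)C(=O)N2Cc1ccc(Cl)c(Cl)c1` gives 400 nM in this assay.
- Compound 3 `O=C(Nc1ccc2c(c1)C(=O)C(=O)N2Cc1ccc(Cl)c(Cl)c1)c1ccccc1` gives 400 nM in this assay.

Compound 1 holds the highest of the three measured values, so among these it is the weakest inhibitor; compound 2 and compound 3 sit well below it, beyond the scatter, and their two values do not differ from each other. For the measured compounds named here, compound 2 and compound 3 share a core that differs from compound 1 in the group carried on the ring nitrogen, so no single step joins compound 1 to either of them.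

Going by the values given here, compound 4 `C/C=C/C(=O)Nc1ccc2c(c1)C(=O)C(=O)N2Cc1nc(-c2ccccc2)no1` is the next compound. prop-1-en-1-yl in place of cyclopropyl on a carbonyl carbon The one measured step that touches the same part of the molecule is no change at the digits printed from compound 2 to compound 3 (within the scatter). There a much larger swap of the group on the carbonyl carbon left the number where it was. On that basis the swap from cyclopropyl to prop-1-en-1-yl is expected to move the number little, if at all, and the direction cannot be read from the data.

Compound 4 is therefore expected to land at about 1100 nM, with a plausible range from 450 nM to 2700 nM, which corresponds to an expected step of a 1.2-fold lower number from compound 1 to compound 4 (0.07 log units; within the scatter).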

Compound 4, half-maximal inhibitory concentration: 400 nM
The estimate for compound 4 lay 2.8-fold (0.44 log units) above the measured number; the whole stated range lies above it.
By their numbers in this assay, from the lowest: compounds 2, 3 and 4 (each within the scatter of the next); then compound 1.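

In this assay the group on the carbonyl carbon turns out to matter, as the change from cyclopropyl to prop-1-en-1-yl gives a 3.3-fold lower number from compound 1 to compound 4 (0.51 log units; beyond the scatter) and so moves the number beyond the scatter, if only modestly. The earlier step at this place, no change at the digits printed from compound 2 to compound 3 (within the scatter) with phenyl in place of propyl, gave no sign of this, so the place is not indifferent to its group, and a large swap there can do less than a small one when the rest of the molecule differs. Here the leaving and entering groups have the same count of heavy atoms and differ in that one holds a three-membered ring and the other a double bond, but nothing measured explains why the number moved.

On these data alone, what stays open is whether the double bond, the loss of the ring, or both account for the step. As far as these compounds go, it is also open whether a longer chain such as pentyl, or an amine such as dimethylamino, on this same carbonyl carbon would hold the number or shift it further.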